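The source may hold more compounds than are shown below. What is called first, only, known or untested is meant among the compounds shown, and "the series" means these compounds.

Working notes on the series. Three compounds of the shared core have numbers in a functional assay on HT-29 cells (Homo sapiens) for cytotoxicity, read by MTT assay, with a stated time of 24 h, tested at 1.6 ug/mL; on this read-out higher numbers stand for a stronger effect at the one concentration tested and lower numbers for a weaker effect. Compound 1 `Cn1c(-c2ccc(NC(=O)CSc3nc4ccccc4s3)cc2)nc(-c2ccccc2)c1-c1ccccc1` gives 15.3%. Compound 2 `Cc1nnc(SCC(=O)Nc2ccc(-c3nc(-c4ccccc4)c(-c4ccccc4)n3C)cc2)s1` gives 39.9%. Compound 3 `CN1CCN(CC(=O)Nc2ccc(-c3nc(-c4ccccc4)c(-c4ccccc4)n3C)cc2)CC1` gives 27.4%. Compound 3 therefore stands second of the three numbers: a number 12.1 percentage points higher from compound 1 to compound 3 (beyond the scatter) and a number 12.5 percentage points lower from compound 2 to compound 3 (beyond the scatter), each beyond the scatter. The remaining step is a number 24.6 percentage points higher from compound 1 to compound 2 (beyond the scatter).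

Compound 4 `Cc1ccc(CN2CCN(CC(=O)Nc3ccc(-c4nc(-c5ccccc5)c(-c5ccccc5)n4C)cc3)CC2)cc1` has not yet been measured. It differs from compound 3 by 4-methylphenyl in place of hydrogen on a saturated chain carbon bound to an amine nitrogen in a ring. Within the data shown here, no measured step touches this place on the ring nitrogen; the two steps that end at compound 3 exchange an entire sulfanyl group for 4-methylpiperazin-1-yl and were only modest, so exchanges at this end of the chain have so far moved the number by limited amounts in either direction. An addition on the saturated chain carbon bound to the amine nitrogen is therefore expected to give at most a modest shift in this assay, with no clear direction, most likely within the scatter. The step from compound 3 to compound 4 is expected to be a number 2.6 percentage points higher from compound 3 to compound 4 (within the scatter). For compound 4 the expected value is 30%, with a range from 12% to 48%.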

Compound 4, a percentage reported as activity, at one concentration (the size of the read-out at that concentration, not a potency): 26.4%
For compound 4 the middle estimate is 3.6 percentage points above the measured one; the range from low to high includes it.
By their numbers in this assay, from the lowest: compound 1; then compounds 4 and 3 (each within the scatter of the next); then compound 2.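

In this assay, among these compounds, the change at this place reads a number 1 percentage points lower from compound 3 to compound 4 (within the scatter), the first step at the ring amine end of the chain rather than an exchange of the whole group on the saturated chain carbon bound to the carbonyl carbon. Read as methyl to 4-methylbenzyl, it shows that this place carries the 4-methylbenzyl group, with its seven added heavy atoms and one six-membered aromatic ring, while the number stays within the scatter of compound 3. Nothing in the data gives a reason for this result.

A single para-free comparison cannot show whether another group here, such as a carboxylic acid, a primary amine or a longer alkyl chain, would move the number beyond the scatter. As far as these compounds go, as each number comes from one concentration, potency also remains open.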